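Adding a Nitro Group to a Weaker Analogue

The source may hold more compounds than are shown below. What is called first, only, known or untested is meant among the compounds shown, and "the series" means these compounds.

Measured compounds:
compound 1, `CCn1cc(-c2nc3ccccc3[nH]2)c(=O)c2cc(F)c(N3CCNCC3)cc21`: 800 nM
compound 2, `CCn1cc(-c2nc3ccccc3[nH]2)c(=O)c2cc(F)c(N3CCNC(C)C3)c(F)c21`: 11600 nM
compound 3, `CCn1cc(-c2nc3ccc([N+](=O)[O-])cc3[nH]2)c(=O)c2cc(F)c(N3CCNCC3)cc21`: 1600 nM

In a functional assay on A2780 cells (Homo sapiens) for cytotoxicity, read by MTT assay, with a stated time of 48 h (on this read-out higher numbers stand for weaker inhibition and lower numbers for stronger inhibition), compound 1 gives 800 nM, compound 3 gives 1600 nM and compound 2 gives 11600 nM. Compound 3 arises from compound 1 by a single change, (nitro in place of hydrogen on an aromatic carbon), and this move gave a 2.0-fold higher number from compound 1 to compound 3 (0.30 log units; within the scatter). How the core of compound 2 differs from the core of compound 1 is not broken down here. Compound 4, `CCn1cc(-c2nc3ccc([N+](=O)[O-])cc3[nH]2)c(=O)c2cc(F)c(N3CCNC(C)C3)c(F)c21`, has not yet been measured; it arises from compound 2 by the same change, (nitro in place of hydrogen on an aromatic carbon). Because a 2.0-fold higher number from compound 1 to compound 3 (0.30 log units; within the scatter) lay within the scatter, a step of similar size is expected here, namely a 1.7-fold higher number from compound 2 to compound 4 (0.24 log units; within the scatter). Compound 4 is therefore estimated at 20000 nM, most likely between 8000 nM and 50000 nM.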

Compound 4, half-maximal inhibitory concentration: 2300 nM
For compound 4 the middle estimate is 8.7-fold (0.94 log units) above the measured one, outside the stated range (below it).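

In this assay, nitro in place of hydrogen on an aromatic carbon gave a 5.0-fold lower number from compound 2 to compound 4 (0.70 log units; beyond the scatter). On these two cores, the same change does not give a step of the same size: the same change on two cores in this assay, a 2.0-fold higher number (0.30 log units; within the scatter) from compound 1 to compound 3 and a 5.0-fold lower number (0.70 log units; beyond the scatter) from compound 2 to compound 4, 10-fold (1.00 log units) apart, beyond the scatter of two such steps This shows that the result of this change depends on the core it is made on, but two pairs do not show which difference between the cores matters, or why the steps differ.

Going by these compounds, it remains open whether an amine or a carboxylic acid on the same aromatic carbon would follow the nitro group on either core. On these data alone, it also remains open how the nitro change would behave on further cores.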